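A few compounds are considered here, and "the series" means these few. Any claim that something is new, unique, unknown or untested is made for them only; others in the source may bear on it.

Compound 1 `c1ccc(-c2cn3ccnc3c(-c3ccc4ncn(C5CCCCC5)c4c3)n2)cc1`: 7.87%
Compound 2 `CCc1ccc(-c2cn3ccnc3c(-c3ccc4ncn(Cc5ccccc5)c4c3)n2)cc1`: 14.9%

In a functional assay on OVCAR-5 cells (Homo sapiens) for inhibition, read by sulforhodamine B assay, with a stated time of 48 h, tested at 10 uM (on this read-out lower numbers stand for less inhibition and higher numbers for more inhibition at the one concentration tested (going by the name of the read-out)), compound 2 gives 14.9%, the higher of the two numbers, though compound 1 with 7.87% lies within the scatter of it, so no order between them can be claimed. Compound 3 `Cc1cccc(-c2cn3ccnc3c(-c3ccc4ncn(Cc5ccccc5)c4c3)n2)c1` is not yet measured. It differs from compound 2 in one place: 3-methylphenyl in place of 4-ethylphenyl on an aromatic carbon. Going by the values given here, with no step between measured compounds to draw on, the change is expected to bring no movement beyond the scatter, so a number 2.9 percentage points lower from compound 2 to compound 3 (within the scatter) is the estimated step. Compound 3 is expected to give about 12%, between 2% and 25%.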

Compound 3, a percentage reported as inhibition, at one concentration (the size of the read-out at that concentration, not a potency): 6.64%
Estimate against measurement, compound 3: 5.4 percentage points above; the range from low to high includes it.
By their numbers in this assay, from the lowest: compounds 3, 1 and 2 (each within the scatter of the next).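

In this assay, going by these compounds alone, placing 3-methylphenyl in place of 4-ethylphenyl on this aromatic carbon gives a number 8.3 percentage points lower from compound 2 to compound 3 (within the scatter), the first step that can be read at this position. The chain and its place on the phenyl ring change together in this step, so the two cannot be separated, and neither shows an effect that can be told from the scatter. Nothing at hand bears on the reason for this result. Still open, on these data alone, is whether an amine or a carboxylic acid on this phenyl ring would move the number beyond the scatter.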